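Furanyl for Pyridinyl on a Shared Core

The source may report more compounds than this note shows. Statements on the series, on what has been measured and on what is new or still open speak of the compounds shown alone.

Compound 1 `O=c1[nH]/c(=C\c2cccc(Oc3ccc(F)cc3)c2)c(=O)[nH]/c1=C\c1cccnc1` gives only a limit in a functional assay on NCI-H460 cells (Homo sapiens) for cytotoxicity, read by MTT assay, with a stated time of 72 h (on this read-out lower numbers stand for stronger inhibition and higher numbers for weaker inhibition), namely > 1000 nM. Compound 2 `Cc1ccc(/C=c2\[nH]c(=O)/c(=C/c3cccc(C(=O)c4ccc(F)cc4)c3)[nH]c2=O)o1` gives 5.3 nM in this assay. Compound 1 therefore stands at the limit of > 1000 nM in this assay, at which 1 of the 2 values shown sits, the weaker end of what has been measured. Compound 3 `COCc1ccc(/C=c2\[nH]c(=O)/c(=C/c3cccc(Oc4ccc(F)cc4)c3)[nH]c2=O)o1` differs from compound 1 by 5-(methoxymethyl)furan-2-yl in place of pyridin-3-yl on a double-bonded chain carbon bound to an aromatic carbon. Going by the values given here, no pair of measured compounds differs in one place, so no step of this kind has been measured. The expected step is an at least 6.6-fold lower number from compound 1 to compound 3 (0.82 log units; beyond the scatter), toward stronger inhibition. For compound 3 the estimated value is 150 nM, with a range from 20 nM to 1000 nM.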

Compound 3, half-maximal inhibitory concentration: 14 nM
Compound 3: middle estimate off by 11-fold (1.03 log units), on the high side; the whole stated range lies above it.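

In this assay, 5-(methoxymethyl)furan-2-yl in place of pyridin-3-yl on a double-bonded chain carbon bound to an aromatic carbon gives an at least 71-fold lower number from compound 1 to compound 3 (1.85 log units; beyond the scatter), the only single-place step shown. The group at this place can therefore move the read-out strongly on the shared core. The full size of the step cannot be stated because compound 1 gives only a limit: the limit of > 1000 nM in this assay, at which 1 of the 3 values shown sits.

As far as these compounds go, what stays open is whether the furan ring or its methoxymethyl chain carries this gain. A plain furan-2-yl or a 5-(hydroxymethyl)furan-2-yl at this place would separate the two.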